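A few compounds are considered here, and "the series" means these few. Any claim that something is new, unique, unknown or untested is made for them only; others in the source may bear on it.

In a functional assay on HEK293 cells for agonist activity at G-protein coupled receptor 39 (Homo sapiens), read by scintillation proximity assay and inositol phosphate accumulation, with a stated time of 75 min (on this read-out higher numbers stand for an effect only at larger amounts of compound and lower numbers for an effect already at smaller amounts), compound 3 `Cc1nn(-c2ncnc3nc[nH]c23)c2c1C(OCc1ccccc1F)CC(=O)N2` gives 78 nM, the second highest of the three numbers: compound 1 `Cc1nn(-c2ncnc3nc[nH]c23)c2c1C(OCc1ccccc1Cl)CC(=O)N2` gives 47 nM, while compound 2 `Cc1cc(C)n(CCOC2CC(=O)Nc3c2c(C)nn3-c2ncnc3nc[nH]c23)n1` gives 2000 nM. The step of a 1.7-fold higher number from compound 1 to compound 3 (0.22 log units; within the scatter) is small, whereas a 43-fold higher number from compound 1 to compound 2 (1.63 log units; beyond the scatter) and a 26-fold lower number from compound 2 to compound 3 (1.41 log units; beyond the scatter) are large. Compound 4 `Cc1nn(-c2ncnc3nc[nH]c23)c2c1C(NC(=O)Cc1cccs1)CC(=O)N2` differs from compound 3 at the same place: (((thiophen-2-yl)methyl)carbonyl)amino in place of (2-fluorobenzyl)oxy on a saturated ring carbon. Both large steps came from changing the group on this saturated ring carbon, so another large step in this assay is the likelier outcome, but the measured steps do not show in which direction a carbonyl-bearing nitrogen link will go. The estimate for compound 4 in this assay is 400 nM, with an expected range from 60 nM to 3000 nM. The expected step is therefore a 5.1-fold higher number from compound 3 to compound 4 (0.71 log units; beyond the scatter).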

Compound 4, half-maximal effective concentration: 244 nM
Estimate against measurement, compound 4: 1.6-fold (0.21 log units) above, within the range that was stated.
By their numbers in this assay, from the lowest: compounds 1 and 3 (each within the scatter of the next); then compound 4; then compound 2.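

In this assay the saturated ring carbon tolerates a change of both link and ring: with a 3.1-fold higher number from compound 3 to compound 4 (0.50 log units; beyond the scatter) and a 5.2-fold higher number from compound 1 to compound 4 (0.72 log units; beyond the scatter) as the measured cost, an amide link bearing a thiophene ring stays within a modest step of both benzyl ethers. Compound 2 and compound 4 both carry a five-membered aromatic ring, yet an 8.2-fold lower number from compound 2 to compound 4 (0.91 log units; beyond the scatter) separates them, so such a ring alone does not set the number. No evidence here explains these differences.

Link and ring change together in compound 4, so the share of each stays open. From the compounds shown here alone, how a plain amine or a longer chain on this carbon would compare also stays open.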